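Dichlorophenyl Exchanged for Trifluoromethylphenyl on a Shared Core

The compounds below may be only part of what the source reports. "The series", "measured", "known", "first", "only" and "open" are said of these compounds alone.

Of the compounds shown here, three have so far been measured in a functional assay on BGC-823 cells (Homo sapiens) for antiproliferative activity, read by MTT assay, tested at 1 uM; a higher number here means a stronger effect of the compound at the concentration tested, a lower number a weaker effect. Compound 1 `COc1ccc(/C=N/NC(=O)c2cc(OC)c(OC)c(OC)c2)c(OC)c1` gives -6.9%, compound 2 `COc1cc(C2=NN(C(C)=O)C(c3cc(Cl)cc(Cl)c3)O2)cc(OC)c1OC` gives 0%, and compound 3 `COc1cc(C(=O)N/N=C/c2cccc(F)c2)cc(OC)c1OC` gives 13.6% at the same concentration. Compound 2 stands second highest of the three numbers, with compound 1 its nearest neighbour within the scatter and compound 3 its furthest, beyond the scatter above it. Compound 4 `COc1cc(C2=NN(C(C)=O)C(c3ccccc3C(F)(F)F)O2)cc(OC)c1OC` has not yet been measured in this assay and differs from compound 2 in one place, namely 2-(trifluoromethyl)phenyl in place of 3,5-dichlorophenyl on a saturated ring carbon on the shared core. Within the data shown here, no step between measured compounds is available to guide the expectation, and all three measured values sit near zero, so the step expected in this assay is small (a number 3 percentage points higher from compound 2 to compound 4 (within the scatter)), in no direction beyond the scatter. Compound 4 is accordingly estimated at 3%, with -12% and 18% as the ends of its range.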

Compound 4, a percentage reported as inhibition, at one concentration (the size of the read-out at that concentration, not a potency): 31.8%
Beside the measured number, compound 4's estimate is 28.8 percentage points below it, outside the stated range (above it).
By their numbers in this assay, from the lowest: compounds 1 and 2 (each within the scatter of the next); then compound 3; then compound 4.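

In this assay, the exchange of 3,5-dichlorophenyl for 2-(trifluoromethyl)phenyl on the saturated ring carbon gives a number 31.8 percentage points higher from compound 2 to compound 4 (beyond the scatter), the first step read on this shared core. Among these compounds, it shows that the aryl group at this position can alter the read-out well beyond the scatter, which the earlier compounds, linked by no step, could not show. Nothing available accounts for the size of this step. The compounds shown leave open how an unsubstituted phenyl or a phenyl bearing a carboxylic acid would behave at this carbon. They also cannot separate the effect of adding trifluoromethyl from that of removing the two chlorines.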